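Trifluoromethyl in Place of Chloro on a Shared Core

The source may hold more compounds than are shown below. What is called first, only, known or untested is meant among the compounds shown, and "the series" means these compounds.

Three compounds have been measured in a functional assay on MCF7 cells (Homo sapiens) for cytotoxicity, read by sulforhodamine B assay, with a stated time of 48 h; a lower number here means a stronger inhibitor of growth, a higher number a weaker inhibitor of growth:
compound 1, `O=C1C(=O)N(CN2CCN(c3ccnc4cc(C(F)(F)F)ccc34)CC2)c2cccc(Cl)c21`, gives 16900 nM;
compound 2, `NC(=S)N/N=C1/C(=O)N(CN2CCN(c3ccnc4cc(Cl)ccc34)CC2)c2cc(Br)ccc21`, gives 11400 nM;
compound 3, `NC(=S)N/N=C1/C(=O)N(CN2CCN(c3ccnc4cc(Cl)ccc34)CC2)c2ccccc21`, gives 23000 nM.

Compound 3 stands highest of the three numbers, with compound 1 nearest and compound 2 furthest, but both gaps lie within the usual scatter, so no order among the three can be read from them. For the measured compounds named here, the only measured step between compounds differing in one place, a 2.0-fold higher number from compound 2 to compound 3 (0.30 log units; within the scatter), also lies within the scatter.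

Compound 4, `NC(=S)N/N=C1/C(=O)N(CN2CCN(c3ccnc4cc(C(F)(F)F)ccc34)CC2)c2ccccc21`, differs from compound 3 by trifluoromethyl in place of chloro on an aromatic carbon. Going by the values given here, no measured step shows this exchange on its own. Compound 1 carries the trifluoromethyl, but it differs from compound 3 in other places as well, so only the two values can be set side by side, and the number for compound 1 and the number for compound 3 lie within the scatter of each other. With nothing pointing beyond the scatter, the step of a 1.2-fold lower number from compound 3 to compound 4 (0.06 log units; within the scatter) is expected to stay within it, in no clear direction. Compound 4 is therefore estimated at 20000 nM, with a range from 8000 nM to 50000 nM.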

Compound 4, concentration for 50% growth inhibition: 13900 nM
Beside the measured number, compound 4's estimate is 1.4-fold (0.16 log units) above it; measured number inside the range.
By their numbers in this assay, from the lowest: compounds 2, 4, 1 and 3 (each within the scatter of the next).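

In this assay, the exchange of chloro for trifluoromethyl can now be read on its own, on an aromatic carbon of the six-membered ring of carbon only, with everything else in the shared core unchanged: a 1.7-fold lower number from compound 3 to compound 4 (0.22 log units; within the scatter). Until now the trifluoromethyl group had appeared only in compound 1, which differs from compound 3 in other places as well, whereas this step shows that, at this position and on this core, the two groups cannot be told apart in this assay. The only other single exchange shown, hydrogen in place of bromo, also stays within the scatter at a 2.0-fold higher number from compound 2 to compound 3 (0.30 log units; within the scatter), and nothing available here bears on the reason for either result.

The compounds shown leave open whether a different kind of group at this position, such as an amine, a methoxy group or a carboxylic acid, would move the number beyond the scatter. They also leave open whether chloro and trifluoromethyl would remain indistinguishable on the core of compound 1, where only the trifluoromethyl form appears here.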